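The source may hold more compounds than are shown below. What is called first, only, known or untested is meant among the compounds shown, and "the series" means these compounds.

Three compounds of the series have so far been run in a functional assay on MCF7 cells (Homo sapiens) for cytotoxicity, read by MTT assay, with a stated time of 72 h; a higher number here means a weaker inhibitor, a lower number a stronger inhibitor. Compound 1 `Cc1ccccc1Nc1nc(SCc2ccc(C(F)(F)F)cc2)nc2ccccc12` gives 37500 nM in this assay. Compound 2 `Fc1ccc(Nc2nc(SCc3ccc(C(F)(F)F)cc3)nc3ccccc23)cc1` gives 36300 nM in this assay; the step of a 1.0-fold lower number from compound 1 to compound 2 (0.01 log units; within the scatter) is within the scatter, so the two values are not distinguished. Compound 3 `O=[N+]([O-])c1ccc(Nc2nc(SCc3ccc(C(F)(F)F)cc3)nc3ccccc23)cc1` gives 17900 nM in this assay, the lowest of the three numbers; the steps of a 2.1-fold lower number from compound 1 to compound 3 (0.32 log units; beyond the scatter) and a 2.0-fold lower number from compound 2 to compound 3 (0.31 log units; beyond the scatter) are both modest but beyond the scatter.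

Compound 4 `COc1ccc(Nc2nc(SCc3ccc(C(F)(F)F)cc3)nc3ccccc23)cc1OC` has not yet been measured. Its difference from compound 3 is 3,4-dimethoxyphenyl in place of 4-nitrophenyl on a nitrogen on an aromatic ring. Among the measured steps, the one that bears on it most directly is a 2.0-fold lower number from compound 2 to compound 3 (0.31 log units; beyond the scatter), where the nitro group entered on the same ring; a 2.1-fold lower number from compound 1 to compound 3 (0.32 log units; beyond the scatter) also ends at compound 3. Both of these steps lowered the number only modestly, and compound 4 removes the nitro group again, so the expected step of a 1.7-fold higher number from compound 3 to compound 4 (0.22 log units; within the scatter) is a modest rise back toward the values of compound 1 and compound 2, though it may well fall within the scatter. Within the data shown here, no measured step carries a dimethoxy group, so the direction rests on the nitro steps alone. Compound 4 is therefore expected to give about 30000 nM in this assay, with a range from 12000 nM to 75000 nM.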

Compound 4, half-maximal inhibitory concentration: > 50000 nM
Compound 4: a limit, no number; the forecaster's own chance of this, stated with the estimate: 5%; middle value at least 1.6-fold (0.22 log units) away from the limit.
By their numbers in this assay, from the lowest: compound 3; then compounds 2 and 1 (each within the scatter of the next). At a limit, above all of these: compound 4.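

Working notes: in this assay compound 4 gives only a limit of the assay and not a number: the limit of > 50000 nM in this assay, at which 1 of the 4 values shown sits. On a nitrogen on an aromatic ring, 3,4-dimethoxyphenyl in place of 4-nitrophenyl gives an at least 2.7-fold higher number from compound 3 to compound 4 (0.44 log units; beyond the scatter), so this position does respond to the change, and the lower number of compound 3 does not carry over to the dimethoxy ring. The other two comparisons, an at least 1.3-fold higher number from compound 2 to compound 4 (0.13 log units; that floor lies within the scatter) and an at least 1.3-fold higher number from compound 1 to compound 4 (0.12 log units; that floor lies within the scatter), have floors inside the scatter, so the limit does not yet separate the dimethoxy ring from the 4-fluorophenyl or 2-methylphenyl rings, although both steps could prove larger than these floors.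

From the compounds shown here alone, the true value of compound 4 stays open, and so does whether one methoxy group alone, at either of the two places it occupies here, would behave like the pair. Also open is whether a nitrile, a carboxylic acid or an amine in place of the nitro group would keep the lower number of compound 3, which among the compounds shown rests on the nitro group alone.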